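The compounds below may be only part of what the source reports. "The series", "measured", "known", "first", "only" and "open" are said of these compounds alone.

Measured so far:
compound 1 `CCCCCCCCCCCCCCCC(=O)O[C@H](COP(=O)(O)O)C(F)F` — > 10000 nM
compound 2 `CCCCCCCC/C=C/CCCCCCCC(=O)OC[C@@H](F)COP(=O)(O)O` — > 10000 nM

In an in vitro functional assay on Sf9 cells for agonist activity at lysophosphatidic acid receptor 3 (Homo sapiens), read by calcium flux (a lower number here means that less compound is needed, a higher number that more compound is needed for the effect), compound 1 gives > 10000 nM, which is a limit of the assay and not a number. Compound 2 gives > 10000 nM in this assay, again a limit rather than a measured value. Compound 2 therefore cannot be placed against compound 1 on the numbers: both sit at the same limit (the limit of > 10000 nM in this assay, at which 2 of the 2 values shown sit), and the two compounds show nothing beyond that.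

Compound 3 `CCCCCCCC/C=C/CCCCCCCC(=O)OC[C@H](F)COP(=O)(O)O` differs from compound 2 only in configuration: the two compounds have the same atoms and bonds and differ only in configuration as drawn: 1 of 2 stereo elements differ; a stereocentre at a saturated chain carbon is drawn R in compound 2 and S in compound 3. For the measured compounds named here, no measured pair in the set differs by such a change, so the size and direction of the step are not given by the data. Compound 3 is expected to sit somewhat off the limit, with the estimate an at least 2.5-fold lower number from compound 2 to compound 3 (0.39 log units; beyond the scatter) carrying a wide range. For compound 3 the value in this assay is expected at about 4000 nM, between 300 nM and 20000 nM.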

Compound 3, half-maximal effective concentration: about 1000 nM
Compound 3: the middle estimate sits 4.0-fold (0.60 log units) above what was measured; the range from low to high includes it.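

In this assay, changing only the stereocentre at a saturated chain carbon from R to S gives an at least 10-fold lower number from compound 2 to compound 3 (1.00 log units; beyond the scatter), so this position responds to configuration in a way that compounds 1 and 2 alone could not show. Going by these compounds, compound 2 gives > 10000 nM, which is a limit of the assay and not a number, so the true size of the step remains unknown. The step can be assigned to the configuration at this carbon alone because no atom or bond changes: the fact that compounds 2 and 3 differ only in the configuration as drawn.

On these data alone, it remains open whether the S configuration would keep its advantage with a hydroxyl or methoxy group in place of the fluorine at this carbon. The compounds shown also leave open whether it would hold with a longer chain on the ester or with a carboxylic acid in place of the phosphate.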